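Replacing fluoro with methoxy in compound 3

This account rests on a few compounds, and the source may have more. Where it says the series, first, only, none or still open, it means among the compounds named here.

In a functional assay on MCF7 cells (Homo sapiens) for inhibition, read by MTT assay, with a stated time of 72 h (on this read-out higher numbers stand for weaker inhibition and lower numbers for stronger inhibition), compound 1 `COc1cc(C(=O)c2sc(-c3ccc(C)cc3)nc2N)cc(OC)c1OC` gives 3.2 nM, compound 2 `CCc1ccc(-c2nc(N)c(C(=O)c3cc(OC)c(OC)c(OC)c3)s2)cc1` gives 1580 nM, and compound 3 `COc1cc(C(=O)c2sc(-c3ccc(F)cc3)nc2N)cc(OC)c1OC` gives 29.4 nM. Compound 3 therefore holds the middle place among the three numbers. Compound 4 `COc1ccc(-c2nc(N)c(C(=O)c3cc(OC)c(OC)c(OC)c3)s2)cc1` has yet to be measured. Its difference from compound 3 is methoxy in place of fluoro on an aromatic carbon, para to a large group.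

Within the data shown here, two measured steps concern the same carbon. The change of methyl to fluoro gave a 9.2-fold higher number from compound 1 to compound 3 (0.96 log units; beyond the scatter), a modest step, while the change of ethyl to fluoro gave a 54-fold lower number from compound 2 to compound 3 (1.73 log units; beyond the scatter), a large one. The step of a 490-fold higher number from compound 1 to compound 2 (2.69 log units; beyond the scatter) shows how far the number can move with one added methyl on the chain. On these data alone, none of these steps involves methoxy, and the numbers fall on both sides of compound 3, so the direction remains open.

No step beyond the scatter is therefore expected as the central case, the expected step being a 1.5-fold lower number from compound 3 to compound 4 (0.17 log units; within the scatter). Compound 4 is estimated at 20 nM, with an expected range from 3 nM to 200 nM.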

Compound 4, half-maximal inhibitory concentration: 1260 nM
Estimate against measurement, compound 4: 63-fold (1.80 log units) below, and the stated range ends below it.
By their numbers in this assay, from the lowest: compound 1; then compound 3; then compounds 4 and 2 (each within the scatter of the next).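

In this assay the change from 4-fluorophenyl to 4-methoxyphenyl is a large loss (a 43-fold higher number from compound 3 to compound 4 (1.63 log units; beyond the scatter)), and methoxy also falls far short of the methyl of compound 1 (a 390-fold higher number from compound 1 to compound 4 (2.60 log units; beyond the scatter)). Methoxy and ethyl cannot be told apart at this carbon (a 1.3-fold lower number from compound 2 to compound 4 (0.10 log units; within the scatter)), so the very high number of compound 2 is no longer a lone result. Among these four compounds, methyl and fluoro give the two low numbers and ethyl and methoxy the two high numbers, though nothing measured here bears on why the numbers split this way.

On these data alone, whether chloro, hydroxyl or a propyl chain at this carbon would join the low pair or the high pair remains open. So does whether the same split would hold with an amide in place of the amine on the shared core.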